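The source may hold more compounds than are shown below. What is called first, only, known or untested is meant among the compounds shown, and "the series" means these compounds.

Among the compounds with values here, in a functional assay on HCT-116 cells (Homo sapiens) for inhibition, read by colorimetric assay, with a stated time of 3 days (on this read-out lower numbers stand for stronger inhibition and higher numbers for weaker inhibition), compound 1 (`O=C(CCCCCCNC(=O)C(O)(O)C(F)(F)F)Nc1ccccc1Br`) gives 14500 nM, the only actual number available so far. Compound 2 (`NC(=O)C(=O)NCCCCCCCC(=O)Nc1ccccc1`) is reported only as a limit of the assay, > 100000 nM. Compound 3 (`O=C(CCCCCCNC(=O)C(O)(O)C(F)(F)F)Nc1ccc(F)cc1F`) has 2,4-difluorophenyl in place of 2-bromophenyl on an amide-type nitrogen. Within the data shown here, no measured step covers this change, so no shift beyond the usual scatter is expected in this assay, and no direction is favoured. The estimated change is a 1.0-fold lower number from compound 1 to compound 3 (0.02 log units; within the scatter). For compound 3 the estimated value is 14000 nM, with an expected range from 5000 nM to 40000 nM.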

Compound 3, half-maximal inhibitory concentration: 18500 nM
Compound 3: middle estimate off by 1.3-fold (0.12 log units), on the low side; the measured number falls inside the stated range.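

Within the data shown here, the step from 2-bromophenyl to 2,4-difluorophenyl on the amide-type nitrogen gives a 1.3-fold higher number from compound 1 to compound 3 (0.11 log units; within the scatter) in this assay, the first measured step at this place. This place therefore accepts a change from bromine to two fluorine atoms with no shift beyond the scatter, so the bromine is not required for the activity seen in compound 1. Nothing available gives a reason for this result.

The compounds shown leave open whether a phenyl ring carrying an amine or a carboxylic acid would be accepted here as well. They also leave open what a longer chain would do on the same core.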